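Arylpiperazine amides at the serotonin 7 receptor: compound 4

This account rests on a few compounds, and the source may have more. Where it says the series, first, only, none or still open, it means among the compounds named here.

Three compounds have numbers in an assay on HEK293 cells for displacement of a labelled ligand from 5-hydroxytryptamine receptor 7 (Rattus norvegicus); a lower number here means a stronger inhibitor, a higher number a weaker inhibitor. Compound 1 `COc1ccccc1N1CCN(CCCC(=O)NC2CCCc3c(OC)cccc32)CC1` gives 35 nM in this assay, and compound 2 `COc1ccc2c(c1)C(NC(=O)CCCCN1CCN(c3ccccc3OC)CC1)CCC2` gives 38.4 nM. Compound 3 `O=C(CCCCCN1CCN(c2nc3ccccc3o2)CC1)NC1CCCc2ccccc21` gives 820 nM, the highest of the three numbers; it stands well beyond the scatter from both compound 2 and compound 1, so among the measured set compound 3 is the weakest inhibitor. Compound 1 and compound 2 lie within the scatter of each other.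

Compound 4 `NC(=O)c1ccccc1N1CCN(CCCCCC(=O)NC2CCCc3ccccc32)CC1` keeps the chain and the amide of compound 3 and differs in one place: 2-carbamoylphenyl in place of 1,3-benzoxazol-2-yl on an amine nitrogen in a ring. For the measured compounds named here, no step between two measured compounds shows this exchange on its own, so the expectation rests on the spread of the measured numbers. Compound 3 already sits at the weak end, and the entering group brings the series closer to the substituted-phenyl pattern of compound 1 and compound 2, which give the lower numbers. The step of a 4.1-fold lower number from compound 3 to compound 4 (0.61 log units; beyond the scatter) is therefore expected to lower the number beyond the scatter. Compound 4 is expected to give about 200 nM in this assay, with a range from 50 nM to 800 nM.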

Compound 4, inhibition constant: 229 nM
Estimate against measurement, compound 4: 1.1-fold (0.06 log units) below, and the stated range covers the measured number.
By their numbers in this assay, from the lowest: compounds 1 and 2 (each within the scatter of the next); then compound 4; then compound 3.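

For the compounds shown here, with the chain and the amide held fixed, 2-carbamoylphenyl in place of 1,3-benzoxazol-2-yl on the amine nitrogen in the ring gives a 3.6-fold lower number from compound 3 to compound 4 (0.55 log units; beyond the scatter) in this assay, the only one-place step so far. The step shows that this position alone can move the number beyond the scatter, even though the two groups match in heavy atoms and differ in their rings and hydrogen-bond donors. No measurement bears on the reason for the step.

The step cannot separate the effect of the carbamoyl group from that of replacing the two-ring group with a single ring. A plain phenyl, or a phenyl bearing a nitrile or a carboxylic acid at the same place, on the chain of compound 4 would leave that question open no longer.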